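A few compounds are considered here, and "the series" means these few. Any claim that something is new, unique, unknown or untested is made for them only; others in the source may bear on it.

Compound 1 `CCCCCCCCCCCC[C@@H](O)[C@H]1CC[C@H]([C@H](O)CCCCCCCCCCNC(=O)c2ccnn2C)O1` gives 3890 nM in the growth test below.
Compound 2 `CCCCCCCCCCCC[C@@H](O)[C@H]1CC[C@H]([C@H](O)CCCCCCCCCCN(C)C(=O)c2ccnn2C)O1` gives 1700 nM in the same test.

In a functional assay on MKN-74 cells (Homo sapiens) for inhibition, read by sulforhodamine B assay, with a stated time of 48 h (on this read-out lower numbers stand for stronger inhibition of growth and higher numbers for weaker inhibition of growth), compound 1 gives 3890 nM and holds the higher of the two numbers. Compound 3 `CCCCCCCCCCCC[C@@H](O)[C@H]1CC[C@H]([C@H](O)CCCCCCCCCCNCc2ccnn2C)O1` has (1-methyl-1H-pyrazol-5-yl)methyl in place of (1-methyl-1H-pyrazol-5-yl)carbonyl on an amine nitrogen. Among the compounds with values here, the only measured step, a 2.3-fold lower number from compound 1 to compound 2 (0.36 log units; beyond the scatter), is modest; it alters that nitrogen but keeps the carbonyl, so it bears only indirectly. Within the data shown here, no measurement yet shows what losing the carbonyl does. Only a small expected move toward a lower number follows, with a 1.9-fold lower number from compound 1 to compound 3 (0.29 log units; within the scatter) as the estimated step. Compound 3 is estimated at 2000 nM within a range of 700 nM to 6000 nM for now.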

Compound 3, concentration for 50% growth inhibition: 1290 nM
For compound 3 the middle estimate is 1.6-fold (0.19 log units) above the measured one, and the stated range covers the measured number.
By their numbers in this assay, from the lowest: compounds 3 and 2 (each within the scatter of the next); then compound 1.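

In this assay the carbonyl can go: (1-methyl-1H-pyrazol-5-yl)methyl in place of (1-methyl-1H-pyrazol-5-yl)carbonyl on the amine nitrogen brings a 3.0-fold lower number from compound 1 to compound 3 (0.48 log units; beyond the scatter) and growth inhibition survives without that carbonyl. Set against the methylated amide, the amine shows a 1.3-fold lower number from compound 2 to compound 3 (0.12 log units; within the scatter) so these two changes at the nitrogen cannot be told apart here. Nothing measured here says why either change lowers the number.

Still open, on these data alone, is whether a methyl on the amine nitrogen of compound 3 adds anything, and whether a phenyl ring in place of the pyrazole would hold the number.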